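This account rests on a few compounds, and the source may have more. Where it says the series, first, only, none or still open, it means among the compounds named here.

Of the compounds shown here, three sharing one core have been tested in a functional assay on MCF7 cells (Homo sapiens) for cytotoxicity, read by MTT assay, with a stated time of 48 h; a lower number here means a stronger inhibitor, a higher number a weaker inhibitor. Compound 1 `N#Cc1ccc(OCc2nnc(-c3ccccc3)o2)cc1F` reads > 50000 nM, which is a limit and not a number. Within the data shown here, compound 2 `COc1ccc(-c2nnc(COc3ccc(C#N)c(F)c3)o2)cc1` gives 42200 nM, the only actual number in the set. Compound 3 `Cc1ccc(-c2nnc(COc3ccc(C#N)c(F)c3)o2)cc1` reads > 50000 nM, again a limit and not a number. Compound 3 therefore stands at the limit of > 50000 nM in this assay, at which 2 of the 3 values shown sit.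

Compound 4 `N#Cc1ccc(OCc2nnc(-c3ccc(F)cc3)o2)cc1F` carries fluoro in place of methyl on an aromatic carbon, para to a large group: fluoro in place of methyl on an aromatic carbon. Among the measured compounds shown here, no measured step makes this exchange directly, so the nearest evidence comes from other changes at the same place. Methyl in place of hydrogen gave a step that the two limits leave unreadable from compound 1 to compound 3. Methoxy in place of hydrogen gave an at least 1.1-fold lower number from compound 1 to compound 2 (0.07 log units; that floor lies within the scatter). Methyl in place of methoxy gave an at least 1.1-fold higher number from compound 2 to compound 3 (0.07 log units; that floor lies within the scatter). None of these is shown beyond the scatter, so no step beyond the scatter is expected in this assay, and the estimated step is an at least 1.1-fold lower number from compound 3 to compound 4 (0.04 log units; that floor lies within the scatter). Compound 4 is expected at 45000 nM, with an estimated range of 25000 nM to 80000 nM.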

Compound 4, half-maximal inhibitory concentration: 20500 nM
The estimate for compound 4 lay 2.2-fold (0.34 log units) above the measured number; measured number outside the range, below it.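

In this assay, no earlier exchange at this position had been shown beyond the scatter, but fluoro on the aromatic carbon para to a large group now is: it gives an at least 2.4-fold lower number from compound 3 to compound 4 (0.38 log units; beyond the scatter), a 2.1-fold lower number from compound 2 to compound 4 (0.31 log units; beyond the scatter) and an at least 2.4-fold lower number from compound 1 to compound 4 (0.38 log units; beyond the scatter). Compound 4 is thus the strongest of the four, and the 4-fluorophenyl group separates itself from hydrogen, methyl and methoxy at this place. Two of these steps are floors and not full sizes, because compound 1 and compound 3 are held at a limit and not a number: the limit of > 50000 nM in this assay, at which 2 of the 4 values shown sit.

How far the gain extends at this position remains open, since the compounds shown carry no chloro, bromo or trifluoromethyl group there. Nor do they show how an amine or a carboxylic acid at the same place would read.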